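Swapping a Pyrimidine for a Pyridine on the Shared Core

The source may hold more compounds than are shown below. What is called first, only, known or untested is meant among the compounds shown, and "the series" means these compounds.

Compound 1 `O=C1C(=O)N(Cc2ccc(-c3cncnc3)cc2)c2ccc(OC(F)(F)F)cc21` is the starting point. In a functional assay on CHO cells for positive allosteric modulation of muscarinic acetylcholine receptor M5 (Homo sapiens), read by FLIPR and calcium flux, with a stated time of 1 h (a lower number here means that less compound is needed, a higher number that more compound is needed for the effect), compound 1 gives 2100 nM, the lowest of the two numbers shown. Compound 3 `O=C1C(=O)N(Cc2ccc(-c3cccnc3)nc2)c2ccc(OC(F)(F)F)cc21` gives 4000 nM in this assay, which lies within the usual scatter of compound 1, so the two cannot be told apart. Compound 2 `O=C1C(=O)N(Cc2ccc(-c3cccnc3)cn2)c2ccc(OC(F)(F)F)cc21` reaches only > 30000 nM in this assay, a limit of the assay rather than a number, as recorded in the limit of > 30000 nM in this assay, at which 1 of the 3 values shown sits.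

Compound 4 `O=C1C(=O)N(Cc2ccc(-c3ccncc3)cc2)c2ccc(OC(F)(F)F)cc21` has not yet been measured. It differs from compound 1 by pyridin-4-yl in place of pyrimidin-5-yl on an aromatic carbon. Among the measured compounds shown here, no measured pair differs in a single place, so no step size can be read off. The step from compound 1 to compound 4 is expected to stay within the scatter, a 1.4-fold lower number from compound 1 to compound 4 (0.15 log units; within the scatter). Compound 4 is therefore expected to give about 1500 nM in this assay, most likely between 500 nM and 5000 nM.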

Compound 4, half-maximal effective concentration: 2800 nM
Estimate against measurement, compound 4: 1.9-fold (0.27 log units) below; the measured number falls inside the stated range.
By their numbers in this assay, from the lowest: compounds 1, 4 and 3 (each within the scatter of the next). At a limit, above all of these: compound 2.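

Among the compounds shown here, the replacement of pyrimidin-5-yl by pyridin-4-yl gives a 1.3-fold higher number from compound 1 to compound 4 (0.12 log units; within the scatter) in this assay, the first step in this set that changes only one place. At this position, on an aromatic carbon para to a large group, the two rings cannot be told apart, even though the entering ring has one hetero atom and the leaving ring has two. Nothing measured here bears on why this swap leaves the number within the scatter.

As far as these compounds go, what remains open is how a plain phenyl ring, an amine or a carboxylic acid would behave at this position.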